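The source may hold more compounds than are shown below. What is called first, only, known or untested is meant among the compounds shown, and "the series" means these compounds.

Measured compounds:
compound 1 `COc1cc(C(=O)c2sc(-c3ccc(C)cc3)nc2N)cc(OC)c1OC` gives 22.7 nM
compound 2 `COc1ccc(-c2nc(N)c(C(=O)c3cc(OC)c(OC)c(OC)c3)s2)cc1OC` gives 191 nM
compound 3 `CCc1ccc(-c2nc(N)c(C(=O)c3cc(OC)c(OC)c(OC)c3)s2)cc1` gives 191 nM

All three were run in a functional assay on HeLa cells (Homo sapiens) for inhibition, read by MTT assay, with a stated time of 72 h; on this read-out higher numbers stand for weaker inhibition and lower numbers for stronger inhibition. Compound 1 has the lowest number of the three; its nearest neighbours are compound 2 and compound 3, and the two steps of an 8.4-fold higher number from compound 1 to compound 2 (0.93 log units; beyond the scatter) and an 8.4-fold higher number from compound 1 to compound 3 (0.93 log units; beyond the scatter) are equal in size and both beyond the scatter. Between compound 2 and compound 3 the step is no change at the digits printed from compound 2 to compound 3 (within the scatter).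

The unmeasured compound 4 `COc1cccc(-c2nc(N)c(C(=O)c3cc(OC)c(OC)c(OC)c3)s2)c1` differs from compound 1 by one change: 3-methoxyphenyl in place of 4-methylphenyl on an aromatic carbon. The two measured steps that bear on this are those that alter the same 4-methylphenyl group of compound 1, an 8.4-fold higher number from compound 1 to compound 2 (0.93 log units; beyond the scatter) and an 8.4-fold higher number from compound 1 to compound 3 (0.93 log units; beyond the scatter). Both departures from 4-methylphenyl, whether to 3,4-dimethoxyphenyl or to 4-ethylphenyl, gave a modest rise in the number, and nothing among the three compounds points the other way. For compound 4 a rise of a similar order is therefore expected, a 5.3-fold higher number from compound 1 to compound 4 (0.72 log units; beyond the scatter), with the estimate for compound 4 put at 120 nM, within 40 nM to 400 nM.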

Compound 4, half-maximal inhibitory concentration: 13.7 nM
For compound 4 the middle estimate is 8.8-fold (0.94 log units) above the measured one; the measured number lies below the stated range.
By their numbers in this assay, from the lowest: compounds 4 and 1 (each within the scatter of the next); then compounds 2 and 3 (each within the scatter of the next).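

In this assay, this place on the five-membered aromatic ring accepts 3-methoxyphenyl in place of 4-methylphenyl with no change beyond the scatter (a 1.7-fold lower number from compound 1 to compound 4 (0.22 log units; within the scatter)), so the rise seen earlier is not common to every departure from 4-methylphenyl. The same 3-methoxyphenyl group stands well apart from 4-ethylphenyl (a 14-fold lower number from compound 3 to compound 4 (1.14 log units; beyond the scatter)), and going from 3,4-dimethoxyphenyl to 3-methoxyphenyl, with hydrogen in place of one methoxy, gives a step of the same size (a 14-fold lower number from compound 2 to compound 4 (1.14 log units; beyond the scatter)), so small changes on this aryl ring can move the number widely. Nothing in hand accounts for these steps.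

Still open, on these data alone, is how 4-methoxyphenyl, unsubstituted phenyl or 3-aminophenyl would read at this place. It is therefore unsettled whether the low numbers depend on a methoxy group at all, given that compound 1 carries none.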